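The source may hold more compounds than are shown below. What is called first, only, known or untested is meant among the compounds shown, and "the series" means these compounds.

Measured so far:
Compound 1, `COc1c(NS(=O)(=O)c2ccc(F)cc2)cc(-c2ccc3nc(NC(C)=O)sc3c2)cc1C(N)=O`: 500 nM in a functional assay on MCF7 cells (Homo sapiens) for antiproliferative activity, read by MTT assay, with a stated time of 72 h; a higher number here means a weaker inhibitor, a lower number a stronger inhibitor
Compound 2, `NC(=O)c1cc(NS(=O)(=O)c2ccc(F)cc2)cc(-c2ccc3nc(NC(=O)C4CC4)sc3c2)c1`: "not determined" (no result reported) in this assay

Compound 2 therefore stands nowhere on the numbers shown; its activity in this assay was not determined, and no step can be drawn from it. Compound 3, `COc1c(NS(=O)(=O)c2ccc(F)cc2)cc(-c2ccc3nc(NC(=O)C4CC4)sc3c2)cc1C(N)=O`, carries one change from compound 2: methoxy in place of hydrogen on an aromatic carbon. Among the measured compounds shown here, with no measured pair sharing this change, the size and direction of the step from compound 2 to compound 3 cannot be told from the data; the expectation is a step no larger than the usual scatter. For the measured compounds named here, the only anchor is compound 1, whose core already bears the methoxy group and which gives 500 nM in this assay. Compound 3 is expected to lie close to that figure, at about 500 nM, most likely between 150 nM and 1600 nM.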

Compound 3, half-maximal inhibitory concentration: 1580 nM
Compound 3: middle estimate off by 3.2-fold (0.50 log units), on the low side, within the range that was stated.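

Among the compounds shown here, with the methoxy group held in place on the core of compound 1, the result gives the first measured pair. In this assay, cyclopropyl in place of methyl on a carbonyl carbon gives a 3.2-fold higher number from compound 1 to compound 3 (0.50 log units; beyond the scatter), so this carbonyl substituent is not indifferent to the read-out, and the smaller group is the better of the two shown. The step from compound 2 to compound 3 cannot be read, so the effect of methoxy in place of hydrogen remains unknown, and nothing available speaks to why the number rises.

From the compounds shown here alone, it remains open how a cyclobutyl ring, an ethyl group or an amine on that carbonyl carbon would compare. Going by these compounds, it is also open whether a hydroxyl or an ethoxy group could stand in place of the methoxy group.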